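The compounds below may be only part of what the source reports. "The series", "measured", "known", "first", "only" and "open" are said of these compounds alone.

Compound 1 `CN1CCN(CCCCCn2c3c(c4ccccc42)C(=O)c2c[n+]([O-])c4ccccc4c2C3=O)CC1` carries a 5-(4-methylpiperazin-1-yl)pentyl chain on the shared core. Among the measured compounds shown here, in a functional assay on A-375 cells (Homo sapiens) for cytotoxicity, read by MTT assay, with a stated time of 72 h (a lower number here means a stronger inhibitor, a higher number a weaker inhibitor), compound 1 gives 1710 nM, the highest of the three numbers known. Compound 2 `O=C1c2c[n+]([O-])c3ccccc3c2C(=O)c2c1c1ccccc1n2CCCCN1CCNCC1` gives 460 nM, and compound 3 `CC1(C)OC[C@@H](Cn2cc(Cn3c4c(c5ccccc53)C(=O)c3c[n+]([O-])c5ccccc5c3C4=O)nn2)O1` gives 450 nM. For the measured compounds named here, the single recorded step from compound 1, a 3.7-fold lower number from compound 1 to compound 2 (0.57 log units; beyond the scatter), changes both the chain and its terminal ring at once. Compound 4 `CN1CCN(CCCn2c3c(c4ccccc42)C(=O)c2c[n+]([O-])c4ccccc4c2C3=O)CC1` differs from compound 1 by 4-methylpiperazin-1-yl in place of 2-(4-methylpiperazin-1-yl)ethyl on a saturated chain carbon, three bonds along the chain from an aromatic nitrogen, a shortening of the chain alone. Going by the values given here, since that one step is the only guide and it mixes two changes, the chemist expects a small step, a 1.4-fold lower number from compound 1 to compound 4 (0.15 log units; within the scatter), toward a lower number, possibly within the scatter. The estimate for compound 4 is 1200 nM, with a range from 400 nM to 3500 nM.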

Compound 4, half-maximal inhibitory concentration: 470 nM
Estimate against measurement, compound 4: 2.6-fold (0.41 log units) above; low and high end bracket the measured number.
By their numbers in this assay, from the lowest: compounds 3, 2 and 4 (each within the scatter of the next); then compound 1.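

With the terminal 4-methylpiperazin-1-yl ring held fixed, going from the 5-(4-methylpiperazin-1-yl)pentyl chain to the 3-(4-methylpiperazin-1-yl)propyl chain alone gives a 3.6-fold lower number from compound 1 to compound 4 (0.56 log units; beyond the scatter) in this assay. So the chain by itself can carry a step of this size, which the earlier mixed step could not separate. The further comparison gives a 1.0-fold higher number from compound 2 to compound 4 (0.01 log units; within the scatter), and no measurement on hand explains either step. The compounds shown leave open whether the number changes stepwise or abruptly with a 4-(4-methylpiperazin-1-yl)butyl chain, and how a 2-(4-methylpiperazin-1-yl)ethyl chain or a terminal morpholine would read.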